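Adding a chloro to compound 1

The compounds below may be only part of what the source reports. "The series", "measured", "known", "first", "only" and "open" are said of these compounds alone.

In a functional assay on KKU100 cells (Homo sapiens) for cytotoxicity, read by MTT assay (a lower number here means a stronger inhibitor, a higher number a weaker inhibitor), compound 1 (`Cc1cc(O)c(C=O)c2c1C(=O)Oc1c(O)c3c(c(C)c1O2)C(=O)CC(C)(C)O3`) gives 6.46 ug/mL and compound 2 (`Cc1cc(O)c(C=O)c2c1C(=O)Oc1c(cc3c(c1C)C(=O)CC(C)(C)O3)O2`) gives 4.63 ug/mL and these two values lie within the usual scatter of each other. Compound 3 (`Cc1c2c(c(O)c3c1C(=O)CC(C)(C)O3)OC(=O)c1c(C)c(Cl)c(O)c(C=O)c1O2`) has chloro in place of hydrogen on an aromatic carbon of the core of compound 1 (chloro in place of hydrogen on an aromatic carbon). For the measured compounds named here, no measured pair shows what such a change does here, so any forecast remains uncertain. A small step toward a lower number in this assay is expected (a 1.4-fold lower number from compound 1 to compound 3 (0.16 log units; within the scatter)) though it may not go beyond the scatter. For compound 3 the estimated value is 4.5 ug/mL (expected range 1.8 ug/mL to 11 ug/mL).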

Compound 3, half-maximal inhibitory concentration: 5.21 ug/mL
The estimate for compound 3 lay 1.2-fold (0.06 log units) below the measured number; measured number inside the range.
By their numbers in this assay, from the lowest: compounds 2, 3 and 1 (each within the scatter of the next).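

In this assay, chloro in place of hydrogen on this aromatic carbon, ortho to a hydroxy group and ortho to a methyl group, gives a 1.2-fold lower number from compound 1 to compound 3 (0.09 log units; within the scatter). Compound 1 and compound 3 therefore cannot be told apart here, so hydrogen and chloro at this position read alike. No measured evidence accounts for this result.

From the compounds shown here alone, whether an amine or a methoxy group on this same carbon would move the number beyond the scatter remains open. So does whether chloro would read the same way on compound 2.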